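A Trifluoromethyl Swap Carried Onto a Second Core

This account rests on a few compounds, and the source may have more. Where it says the series, first, only, none or still open, it means among the compounds named here.

Compound 1 `Oc1cccc2[nH]c(-c3ccc(-c4ccc(-c5ccc(F)cc5)cc4)cc3)nc12` and compound 2 `Oc1cccc2[nH]c(-c3ccc(-c4ccc(-c5ccc(C(F)(F)F)cc5)cc4)cc3)nc12` share one core, while compound 3 `Cc1ccc2[nH]c(-c3ccc(-c4ccc(-c5ccc(F)cc5)cc4)cc3)nc2c1` and compound 4 `Cc1ccc2[nH]c(-c3ccc(-c4ccc(-c5ccc(C(F)(F)F)cc5)cc4)cc3)nc2c1` share another; the difference between the two cores is not broken down here. In a functional assay on HOP-62 cells (Homo sapiens) for inhibition, read by sulforhodamine B assay (on this read-out lower numbers stand for stronger inhibition of growth and higher numbers for weaker inhibition of growth), compound 1 gives 8310 nM and compound 2 gives 3200 nM. The change between them, (trifluoromethyl in place of fluoro on an aromatic carbon), gave a 2.6-fold lower number from compound 1 to compound 2 (0.41 log units; beyond the scatter). In this assay compound 3 gives 33500 nM, the highest of the three numbers. Compound 4 carries the same change on this second core, (trifluoromethyl in place of fluoro on an aromatic carbon), at a place described in identical words. If that step repeats, compound 4 is expected to show a 2.6-fold lower number from compound 3 to compound 4 (0.41 log units; beyond the scatter), resting on a 2.6-fold lower number from compound 1 to compound 2 (0.41 log units; beyond the scatter). The number expected for compound 4 in this assay is therefore 13000 nM, estimated to lie between 6000 nM and 30000 nM.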

Compound 4, concentration for 50% growth inhibition: 24200 nM
Compound 4: the middle estimate sits 1.9-fold (0.27 log units) below what was measured; the measured number falls inside the stated range.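

On the core of compound 3, the change from fluoro to trifluoromethyl gives a 1.4-fold lower number from compound 3 to compound 4 (0.14 log units; within the scatter) in this assay, so on this core alone its effect cannot be told apart from the noise of repeated measurement. Set beside the step on the other core, the result gives no sign that the two cores respond differently: the same change on two cores in this assay, a 2.6-fold lower number (0.41 log units; beyond the scatter) from compound 1 to compound 2 and a 1.4-fold lower number (0.14 log units; within the scatter) from compound 3 to compound 4, 1.9-fold (0.27 log units) apart, within the scatter of two such steps. Among the compounds shown here, this does not show that the change acts equally on both cores, as each core offers only one pair, and the core itself still matters, with a 7.6-fold higher number from compound 2 to compound 4 (0.88 log units; beyond the scatter).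

From the compounds shown here alone, whether other groups at this place, such as a nitrile or a carboxylic acid, would behave alike on both cores remains open. The compounds shown also cannot separate the contribution of the hydroxy group from that of the methyl group to the gap between the cores.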